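The compounds below may be only part of what the source reports. "The series", "measured", "known", "first", "only" and "open" are said of these compounds alone.

Measured so far:
- compound 1, `S=C(N/N=C/c1ccc(Oc2ccc(Cl)cc2)cc1)Nc1ccccc1`, 5.52
- compound 2, `S=C(N/N=C/c1ccc(Oc2ccc(Cl)cc2)cc1)Nc1ccc(Br)cc1`, 6.24
- compound 3, `Cc1cc(Oc2ccc(/C=N/NC(=S)Nc3ccc(Cl)cc3)cc2)ccc1Cl`, 6.59

These three values come from a physicochemical assay for lipophilicity, in phosphate buffer, measured as octanol-water partition, with a stated time of 24 h; on this read-out lower numbers stand for lower lipophilicity and higher numbers for higher lipophilicity. Compound 2 sits second highest of the three: compound 3 lies above it by a margin beyond the scatter, and compound 1 lies below it by a larger margin. Among the measured compounds shown here, the one step measured between compounds that differ in a single place is a number 0.72 log units higher from compound 1 to compound 2 (beyond the scatter), so adding a halogen raised the number in this assay.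

Compound 4, `Fc1ccc(Oc2ccc(/C=N/NC(=S)Nc3ccc(Br)cc3)cc2)cc1`, is compound 2 with one change: fluoro in place of chloro on an aromatic carbon. For the measured compounds named here, no measured step covers a swap of chloro for fluoro, so the expectation rests on the only halogen step seen, which shows how much a heavier halogen adds; fluoro is the lightest halogen and is expected to add less than chloro did. The step from compound 2 to compound 4 is therefore expected to be a number 0.54 log units lower from compound 2 to compound 4 (beyond the scatter), a decrease beyond the scatter. Compound 4 is estimated at 5.7, within 5.3 to 6.1.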

Compound 4, partition coefficient: 5.82
Compound 4: middle estimate off by 0.12 log units, on the low side, within the range that was stated.
By their numbers in this assay, from the lowest: compounds 1 and 4 (each within the scatter of the next); then compound 2; then compound 3.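

Among the compounds shown here, this is the first measured change at the 4-chlorophenoxy end of the molecule, since the earlier single-place step put a bromo in place of hydrogen on a different aromatic carbon. In this assay, the exchange of one halogen for another gives a number 0.42 log units lower from compound 2 to compound 4 (beyond the scatter), so the read-out depends on which halogen sits at this position, even though the two groups match in heavy-atom count, hydrogen-bond donors and acceptors, and net charge. Nothing measured here bears on why the number falls with this exchange.

As far as these compounds go, it remains open how hydrogen, a methoxy group, an amine or a carboxylic acid at this position would compare with fluoro and chloro. From the compounds shown here alone, the exchange also appears in only one setting, with the bromo present, so whether a step of similar size would appear without the bromo remains unknown.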